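A few compounds are considered here, and "the series" means these few. Any claim that something is new, unique, unknown or untested is made for them only; others in the source may bear on it.

The series shares one core, varied only at the aryl group on the exocyclic double bond. Compound 1 `CCCc1ccc(/C=C2\CCCN=C2c2cccnc2)cc1` is compared with compound 2 `COc1ccc(/C=C2\CCCN=C2c2cccnc2)c(OC(C)=O)c1` and compound 3 `Cc1cc(C)c(/C=C2\CCCN=C2c2cccnc2)c(C)c1` in an assay on membranes from brain for displacement of a labelled ligand from Neuronal acetylcholine receptor; alpha4/beta2 (Rattus norvegicus), with a stated time of 3 h; a higher number here means a weaker inhibitor, a lower number a stronger inhibitor. In this assay compound 1 gives 890 nM, compound 2 gives 770 nM and compound 3 gives 520 nM. Compound 1 thus shows the highest number of the three, yet the nearest value, that of compound 2, and the furthest, that of compound 3, both lie within the scatter of it, so no order among these three can be read.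

The next compound, compound 4 `FC(F)Oc1ccc(/C=C2\CCCN=C2c2cccnc2)cc1`, differs from compound 1 by a change on the aromatic ring: difluoromethoxy in place of propyl on an aromatic carbon. For the measured compounds named here, no pairwise step between measured compounds is available, so the weight of this change cannot be read from the data. The three measured compounds, which carry quite different substituents on that ring, all sit within the scatter of one another, and this suggests that a further exchange of the group in this place would again give a step no larger than the scatter. Compound 4 is therefore expected to come in at 700 nM, within a range of 300 nM to 1600 nM. The estimated step from compound 1 to compound 4 is a 1.3-fold lower number from compound 1 to compound 4 (0.10 log units; within the scatter), which is expected to lie within the scatter.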

Compound 4, inhibition constant: 1160 nM
Compound 4: middle estimate off by 1.7-fold (0.22 log units), on the low side, within the range that was stated.
By their numbers in this assay, from the lowest: compounds 3, 2, 1 and 4 (each within the scatter of the next, the first and the last beyond it).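

In this assay the exchange gives a 1.3-fold higher number from compound 1 to compound 4 (0.12 log units; within the scatter) and thus provides the only step shown that changes a single place, where the earlier compounds offered none. Although difluoromethoxy brings oxygen, fluorine and a hydrogen-bond acceptor in place of the all-carbon propyl, this step on an aromatic carbon, para to a large group, stays within the scatter, so neither group can be ranked over the other here. Nothing shown offers an explanation for this result.

The compounds shown leave open whether a group of another kind at this place, such as an amine, a carboxylic acid or a longer alkyl chain, would give a step beyond the scatter. Also open, going by these compounds, is whether the exchange of propyl for difluoromethoxy would read the same on a ring carrying further groups, as the rings of compound 2 and compound 3 do.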